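A few compounds are considered here, and "the series" means these few. Any claim that something is new, unique, unknown or untested is made for them only; others in the source may bear on it.

Of the compounds shown here, three have been measured in an assay for inhibition of Fatty-acid amide hydrolase 1 (Rattus norvegicus); a lower number here means a stronger inhibitor, a higher number a weaker inhibitor. Compound 1 `O=C(CCc1ccc(-c2ccccc2)cc1)c1ncc(-c2ccncc2)o1` gives 2.3 nM, compound 2 `O=C(CCc1ccc(-c2ccccc2)cc1)c1ncc(-c2cccc(-c3nnn[nH]3)n2)o1` gives 25 nM, and compound 3 `CSc1cnc(C(=O)CCc2ccc(-c3ccccc3)cc2)o1` gives 3 nM. Compound 3 thus stands second highest of the three, within the scatter of compound 1 and well apart from compound 2. For the measured compounds named here, the one measured step that bears directly on the next change is a 1.3-fold higher number from compound 1 to compound 3 (0.12 log units; within the scatter), which shows that swapping these two small groups hardly moved the number. Compound 4 `COC(=O)c1cccc(-c2cnc(C(=O)CCc3ccc(-c4ccccc4)cc3)o2)n1` carries a larger change: 6-(methoxycarbonyl)pyridin-2-yl in place of methylsulfanyl on an aromatic carbon. Going by the values given here, compound 2, the only other compound with a bigger group at this place, sits clearly higher than compound 1. For compound 4 a move toward weaker inhibition is therefore expected, a 4.0-fold higher number from compound 3 to compound 4 (0.60 log units; beyond the scatter), giving an estimated 12 nM with a range from 3 nM to 50 nM.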

Compound 4, inhibition constant: 1.2 nM
For compound 4 the middle estimate is 10-fold (1.00 log units) above the measured one; the whole stated range lies above it.
By their numbers in this assay, from the lowest: compounds 4, 1 and 3 (each within the scatter of the next, the first and the last beyond it); then compound 2.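

This position tolerates a much larger group: 6-(methoxycarbonyl)pyridin-2-yl brings more heavy atoms than methylsulfanyl, yet the number does not rise (a 2.5-fold lower number from compound 3 to compound 4 (0.40 log units; beyond the scatter)). Against the smaller pyridin-4-yl group, the difference stays small (a 1.9-fold lower number from compound 1 to compound 4 (0.28 log units; within the scatter)). What sits on the added ring matters far more, as methoxycarbonyl in place of 1H-tetrazol-5-yl shows (a 21-fold lower number from compound 2 to compound 4 (1.32 log units; beyond the scatter)), though no measurement here explains these differences. From the compounds shown here alone, it remains open how a carboxylic acid or an amide in place of methoxycarbonyl would behave, or a pyridin-2-yl group with nothing attached.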